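Carboxy in Place of Propyl on the Thioether Chain

This account rests on a few compounds, and the source may have more. Where it says the series, first, only, none or still open, it means among the compounds named here.

In an assay on microsomes from liver for inhibition of sterol O-acyltransferase 1 (Rattus norvegicus) (on this read-out lower numbers stand for stronger inhibition and higher numbers for weaker inhibition), compound 3 `CCCCCCCCCSc1cc(-c2ccccc2)c(-c2ccccc2)nn1` gives 116000 nM, and the other two numbers lie within the usual scatter of it: compound 1 `CCCCCCCCCn1nc(-c2ccccc2)c(-c2ccccc2)cc1=O` gives 85000 nM in this assay, and compound 2 `CCCCCCSc1cc(-c2ccccc2)c(-c2ccccc2)nn1` gives 62000 nM. Compound 4 `O=C(O)CCCCCCSc1cc(-c2ccccc2)c(-c2ccccc2)nn1` differs from compound 3 in one place: carboxy in place of propyl on a saturated chain carbon, six bonds along the chain from a sulfur. Within the data shown here, the only measured step between neighbouring structures is a 1.9-fold higher number from compound 2 to compound 3 (0.27 log units; within the scatter), which concerns chain length alone and bears only loosely on the present change. Among the measured compounds shown here, no measured pair shows what a carboxy group on a saturated chain carbon six bonds along the chain from a sulfur does on this scaffold. Because compound 3 gives 116000 nM and both other numbers sit within the scatter of it, the step of a 1.7-fold higher number from compound 3 to compound 4 (0.24 log units; within the scatter) is expected to lean toward a higher number, with a wide range that also covers no change beyond the scatter. Compound 4 is therefore estimated at 200000 nM, between 60000 nM and 700000 nM.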

Compound 4, half-maximal inhibitory concentration: > 300000 nM
Compound 4: no number, only a limit; the forecaster's own chance of this, stated with the estimate: 30%; middle value at least 1.5-fold (0.17 log units) from the limit.
By their numbers in this assay, from the lowest: compounds 2, 1 and 3 (each within the scatter of the next). At a limit, above all of these: compound 4.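

In this assay compound 4 gives no number, only a limit of the assay: the limit of > 300000 nM in this assay, at which 1 of the 4 values shown sits. Even so, this is the first change at this end of the thioether chain to reach beyond the scatter: lengthening the chain stayed within it (a 1.9-fold higher number from compound 2 to compound 3 (0.27 log units; within the scatter)), whereas carboxy in place of propyl on a saturated chain carbon, six bonds along the chain from a sulfur, does not (an at least 2.5-fold higher number from compound 3 to compound 4 (0.41 log units; beyond the scatter)). The same holds when the carboxy group is set against hydrogen at that place (an at least 4.8-fold higher number from compound 2 to compound 4 (0.68 log units; beyond the scatter)), so both comparisons point toward weaker inhibition.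

The limit leaves open how much weaker compound 4 is. Going by these compounds, it also remains open whether a methyl ester, a primary amide or an amine at the same place on the chain would shift the number in the same way.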